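Capping a hydroxyl: from compound 2 toward compound 3

The compounds below may be only part of what the source reports. "The series", "measured", "known", "first", "only" and "open" are said of these compounds alone.

Compound 1 `C=CCCn1c(=O)c2[nH]cnc2n(CCC)c1=O`: 60 nM
Compound 2 `CCCn1c(=O)n(CCO)c(=O)c2[nH]cnc21`: 50000 nM

Among the compounds with values here, in an assay on Cerebral cortex for binding affinity to adenosine receptor A1 (Cavia porcellus), read by radioligand binding (a higher number here means a weaker inhibitor, a lower number a stronger inhibitor), compound 2 gives 50000 nM, the highest of the two numbers measured so far, and compound 1 gives 60 nM. Within the data shown here, the only measured step, an 830-fold higher number from compound 1 to compound 2 (2.92 log units; beyond the scatter), shows that a hydroxy in place of a vinyl at that chain position costs a great deal of binding.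

Compound 3 `CCCn1c(=O)n(CCOC)c(=O)c2[nH]cnc21` carries a single change from compound 2: methyl in place of hydrogen on an oxygen on a saturated carbon, that is, hydroxy to methoxy on the 2-hydroxyethyl chain. Among the measured compounds shown here, no measured step covers methylation of this oxygen directly. The closest evidence is the step from compound 1 to compound 2, which shows how much the bare hydroxy weakens binding; a methoxy lies structurally between hydroxy and vinyl, so a partial recovery is expected rather than a full one. Compound 3 is therefore estimated at 10000 nM, between 1500 nM and 50000 nM, which would mean an expected step of a 5.0-fold lower number from compound 2 to compound 3 (0.70 log units; beyond the scatter).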

Compound 3, inhibition constant: 2500 nM
Beside the measured number, compound 3's estimate is 4.0-fold (0.60 log units) above it; the measured number falls inside the stated range.
By their numbers in this assay, from the lowest: compound 1; then compound 3; then compound 2.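

In this assay, capping the hydroxy as methoxy brings back much of the lost binding, with a 20-fold lower number from compound 2 to compound 3 (1.30 log units; beyond the scatter) on adding a single methyl, so this oxygen's hydrogen counts for a lot at this position. The recovery is only partial, however, since there is still a 42-fold higher number from compound 1 to compound 3 (1.62 log units; beyond the scatter) when methoxy replaces vinyl on the chain. Nothing available here explains why the methyl helps so much.

The compounds shown leave open whether a larger cap on the same oxygen, such as ethyl, would recover more binding or less. They also do not tell how an amine or a carboxylic acid in place of the hydroxy on this chain would compare with the methoxy of compound 3.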